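A few compounds are considered here, and "the series" means these few. Any claim that something is new, unique, unknown or untested is made for them only; others in the source may bear on it.

Working notes on the series.

Compound 1 `C=C1C[C@]23C[C@@]1(O)CC[C@@H]2c1cccc(C)c1[C@@H]3Cn1cc(-c2ccc(OC)cc2)nn1` is the reference point. In a functional assay on A549 cells (Homo sapiens) for cytotoxicity, read by MTT assay, with a stated time of 4 days (a lower number here means a stronger inhibitor, a higher number a weaker inhibitor), compound 1 gives > 20000 nM, which is a limit of the assay and not a number. Compound 2 `C=C1C[C@]23C[C@@]1(O)CC[C@@H]2c1cccc(C)c1[C@@H]3Cn1cc(-c2ccc(Br)cc2)nn1` carries bromo in place of methoxy on an aromatic carbon. In this assay compound 2 gives > 20000 nM, again a limit and not a number. The step that the two limits leave unreadable from compound 1 to compound 2 therefore cannot be read; both values sit at the limit of > 20000 nM in this assay, at which 2 of the 2 values shown sit, so the size of any difference between the two compounds is hidden.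

Compound 3 `C=C1C[C@]23C[C@@]1(O)CC[C@@H]2c1cccc(C)c1[C@@H]3Cn1cc(-c2ccccn2)nn1` is the next member. It differs from compound 2 by pyridin-2-yl in place of 4-bromophenyl on an aromatic carbon. Within the data shown here, the only measured step that bears on this change is the one from compound 1 to compound 2, and it gives no readable size, so it sets no direction for the change to compound 3. With both measured compounds at the limit, the expectation for compound 3 in this assay is that it also reaches no measurable number, and the step that the limit leaves unreadable from compound 2 to compound 3 is estimated as none beyond the scatter. Compound 3 is accordingly estimated at 30000 nM, within 10000 nM to 100000 nM, most likely reported as a limit.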

Compound 3, half-maximal inhibitory concentration: > 20000 nM
Compound 3: a limit, no number (the forecaster's own chance of this, stated with the estimate: 80%); the middle value does not contradict the limit.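

In this assay compound 3 gives > 20000 nM as a limit of the assay and not a number. No new step can be read, and the steps among compound 1, compound 2 and compound 3 stay unreadable: the limit of > 20000 nM in this assay, at which 3 of the 3 values shown sit.

From the compounds shown here alone, whether 4-methoxyphenyl, 4-bromophenyl and pyridin-2-yl differ at all on the shared core stays open in this assay.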